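Changing the Group on the Oxygen of Compound 2

The source may report more compounds than this note shows. Statements on the series, on what has been measured and on what is new or still open speak of the compounds shown alone.

In an ADME assay on the whole organism (strain FVB) for pharmacokinetics, with Mus musculus as the target, read by LC-MS, at a dose of 30 mg/kg by the oral route (a higher number here means more compound in the circulation at the dose given, a lower number less compound in the circulation), compound 1 (`c1cc([C@H]2CC[C@]3(CC2)OOC2(O3)C3CC4CC(C3)CC2C4)ccc1OC1CCNCC1`) gives 7200 ng.h/mL and compound 2 (`CC(C)(CN)Oc1ccc([C@H]2CC[C@]3(CC2)OOC2(O3)C3CC4CC(C3)CC2C4)cc1`) gives 4840 ng.h/mL. These two values lie within the scatter of each other, so compound 2 stands level with compound 1. Compound 3 (`CC1(C)CC(O)(COc2ccc([C@H]3CC[C@]4(CC3)OOC3(O4)C4CC5CC(C4)CC3C5)cc2)CC(C)(C)N1`) alters compound 2 in one place: (4-hydroxy-2,2,6,6-tetramethylpiperidin-4-yl)methyl in place of 1-(aminomethyl)-1-methylethyl on an oxygen on an aromatic ring. Within the data shown here, the only measured step bearing on this change concerns the same oxygen: a 1.5-fold lower number from compound 1 to compound 2 (0.17 log units; within the scatter). From the compounds shown here alone, that step offers no sign of a large effect, but the entering group is untested, so no shift beyond the scatter is expected in this assay, with wide uncertainty. The expected step is a 1.2-fold lower number from compound 2 to compound 3 (0.08 log units; within the scatter). The estimate for compound 3 is 4000 ng.h/mL, within a range of 1300 ng.h/mL to 12000 ng.h/mL.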

Compound 3, area under the concentration-time curve: 17300 ng.h/mL
The estimate for compound 3 lay 4.3-fold (0.64 log units) below the measured number, outside the stated range (above it).
By their numbers in this assay, from the lowest: compounds 2 and 1 (each within the scatter of the next); then compound 3.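

Among these compounds, on an oxygen on an aromatic ring, the step to the (4-hydroxy-2,2,6,6-tetramethylpiperidin-4-yl)methyl group is the first here to go beyond the scatter in this assay: a 3.6-fold higher number from compound 2 to compound 3 (0.55 log units; beyond the scatter), and a 2.4-fold higher number from compound 1 to compound 3 (0.38 log units; beyond the scatter). The position therefore accepts this larger group with more compound in the circulation, not less. Nothing available explains this rise.

The compounds shown do not separate the contribution of the hydroxy group from that of the four methyl groups. From the compounds shown here alone, how a (4-hydroxypiperidin-4-yl)methyl group or a carboxylic acid would read on this oxygen remains open.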